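The source may hold more compounds than are shown below. What is called first, only, known or untested is meant among the compounds shown, and "the series" means these compounds.

Measured compounds in a functional assay on SUP-B15 cells (Homo sapiens) for antiproliferative activity, with a stated time of 72 h; a lower number here means that less compound is needed, a higher number that more compound is needed for the effect:

compound 1 `COc1ccc(-c2[nH]c3cc(OC)cc(OC)c3c(=O)c2I)cc1` gives > 86200 nM, which is a limit of the assay.
compound 2 `COc1ccc(-c2c(I)c(=O)c3c(OC)cc(OC)cc3n2S(=O)(=O)c2ccc(OC)cc2)cc1` gives 12300 nM.
compound 3 `COc1ccc(-c2cc(=O)c3c(OC)cc(OC)cc3n2S(=O)(=O)c2ccc(C)c([N+](=O)[O-])c2)cc1` gives > 51700 nM, which is a limit of the assay.

Compound 3 therefore stands at one of the two limits among the three values, and compound 1 sits at the other limit; only compound 2 has a number, and it is the lowest value shown. Among the measured compounds shown here, the single one-change step available is an at least 7.0-fold lower number from compound 1 to compound 2 (0.84 log units; beyond the scatter), though it concerns a compound that also carries iodine on the core, which compound 3 and compound 4 lack.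

Compound 4 `COc1ccc(-c2cc(=O)c3c(OC)cc(OC)cc3n2S(=O)(=O)c2cccc(Br)c2)cc1` differs from compound 3 in one place: 3-bromophenyl in place of 4-methyl-3-nitrophenyl on a sulfonyl sulfur. No measured step exchanges one sulfonyl aryl group for another, so the size of this change cannot be read from the steps shown. For the measured compounds named here, compound 3 is a limit and compound 2, the only numbered value, is itself high, so a weak result is the plainest expectation. For compound 4 the estimate is 45000 nM, within 10000 nM to 150000 nM, with a fair chance that this assay again reports only a limit. The step this estimate means is an at least 1.1-fold lower number from compound 3 to compound 4 (0.06 log units; that floor lies within the scatter), expected rather than known.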

Compound 4, half-maximal effective concentration: > 58600 nM
Compound 4: a limit, no number; the forecaster's own chance of this, stated with the estimate: 55%; at least 1.3-fold (0.11 log units) between middle value and limit.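

Compound 3 and compound 4 both give only a limit in this assay, so no step can be read between them for 3-bromophenyl in place of 4-methyl-3-nitrophenyl on a sulfonyl sulfur. Left open is whether the sulfonyl aryl group matters at all in this assay, and whether the iodine on the core of compound 2 contributes to its numbered value.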